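The compounds below may be only part of what the source reports. "The series", "measured", "known", "first", "only" and "open" are said of these compounds alone.

In a functional assay on L1210 cells (Mus musculus) for antiproliferative activity, read by cell counting, with a stated time of 96 h (a higher number here means a weaker inhibitor, a lower number a stronger inhibitor), three compounds built on a shared core have been measured. Compound 1 `CC(Nc1ccccc1Oc1cccc(F)c1)=C1C(=O)CC(c2ccccc2)CC1=O` gives 330 nM, compound 2 `CC(=O)c1ccc(Oc2ccccc2NC(C)=C2C(=O)CC(c3ccccc3)CC2=O)cc1` gives 190 nM, and compound 3 `COc1ccc(Oc2ccccc2NC(C)=C2C(=O)CC(c3ccccc3)CC2=O)cc1` gives 140 nM. Compound 3 stands clear of compound 1 only. Putting 4-methoxyphenyl in place of 3-fluorophenyl gives a 2.4-fold lower number from compound 1 to compound 3 (0.37 log units; beyond the scatter), while methoxy in place of acetyl gives a 1.4-fold lower number from compound 2 to compound 3 (0.13 log units; within the scatter), so compound 3 cannot be separated from compound 2. Putting 4-acetylphenyl in place of 3-fluorophenyl gives a 1.7-fold lower number from compound 1 to compound 2 (0.24 log units; within the scatter).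

Compound 4 `CCOc1ccccc1NC(C)=C1C(=O)CC(c2ccccc2)CC1=O` departs further from this series: ethyl in place of 4-methoxyphenyl on an oxygen on an aromatic ring. In words, this is ethyl in place of 4-methoxyphenyl on an oxygen on an aromatic ring, or 4-methoxyphenoxy to ethoxy. The measured steps bear on this change only in part. Each keeps an aromatic ring on that oxygen, and none shows what happens when the ring is gone. Even the largest of them, a 2.4-fold lower number from compound 1 to compound 3 (0.37 log units; beyond the scatter), is modest, so it sets no firm limit on a change of this kind. A larger step towards a higher number is therefore expected, with wide uncertainty, and the estimated step is a 3.2-fold higher number from compound 3 to compound 4 (0.51 log units; beyond the scatter). Compound 4 is expected at 450 nM, with an estimated range of 130 nM to 1500 nM.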

Compound 4, half-maximal inhibitory concentration: 190 nM
Compound 4: the middle estimate sits 2.4-fold (0.37 log units) above what was measured, within the range that was stated.
By their numbers in this assay, from the lowest: compounds 3, 2, 4 and 1 (each within the scatter of the next, the first and the last beyond it).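

In this assay, an aromatic ring on this oxygen proves not to be required in these compounds: with ethyl there, the steps read a 1.4-fold higher number from compound 3 to compound 4 (0.13 log units; within the scatter), no change at the digits printed from compound 2 to compound 4 (within the scatter) and a 1.7-fold lower number from compound 1 to compound 4 (0.24 log units; within the scatter), so compound 4 cannot be separated from any of the three compounds that carry a ring at this place. The earlier steps all kept a ring on the oxygen, so only this result shows that going from 4-methoxyphenyl, with its 8 heavy atoms, to ethyl, with 2, leaves the number within the scatter of every compound shown. No measurement offered here accounts for this tolerance.

Since compound 4 lies within the scatter of both compound 1 and compound 3, which are themselves beyond it, its place among them remains unsettled. As far as these compounds go, it also remains open how much the group on this oxygen can vary, and whether the oxygen itself matters: methyl, a longer chain such as butyl, or a chain ending in a carboxylic acid or an amine on the oxygen would bear on the first question, and an amine in place of the oxygen on the second.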